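Hydrazone series: aryl substituent steps on the phenyl ring

The compounds below may be only part of what the source reports. "The series", "measured", "known", "first", "only" and "open" are said of these compounds alone.

Compound 1 `c1ccc(NN=C(c2nc3ccccc3[nH]2)c2nc3ccccc3[nH]2)cc1` gives 160000 nM in a functional assay on U-118-MG cells (Homo sapiens) for cytotoxicity, read by MTT assay, with a stated time of 72 h; on this read-out higher numbers stand for weaker inhibition and lower numbers for stronger inhibition. Compound 2 `Cc1ccc(NN=C(c2nc3ccccc3[nH]2)c2nc3ccccc3[nH]2)cc1`, which carries methyl in place of hydrogen on an aromatic carbon, gives 250000 nM in this assay. For the measured compounds named here, compound 2 holds the highest of the two numbers measured so far, but its only neighbour is compound 1, and a 1.6-fold higher number from compound 1 to compound 2 (0.19 log units; within the scatter), so the two cannot be ordered on these data.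

Compound 3 `COc1ccc(NN=C(c2nc3ccccc3[nH]2)c2nc3ccccc3[nH]2)cc1` is not yet measured. It differs from compound 2 by methoxy in place of methyl on an aromatic carbon, para to a large group. Going by the values given here, the single measured step that bears on this position is a 1.6-fold higher number from compound 1 to compound 2 (0.19 log units; within the scatter): a change at the same aromatic carbon moved the number no further than repeat measurements do. Among the compounds with values here, with only that step to go on, no movement beyond the scatter is expected in this assay for compound 3, and the step expected for compound 3 is a 1.1-fold lower number from compound 2 to compound 3 (0.06 log units; within the scatter). Compound 3 is therefore estimated at 220000 nM, with a range from 80000 nM to 600000 nM.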

Compound 3, half-maximal inhibitory concentration: 250000 nM
Compound 3: the middle estimate sits 1.1-fold (0.06 log units) below what was measured; low and high end bracket the measured number.
By their numbers in this assay, from the lowest: compounds 1, 2 and 3 (each within the scatter of the next).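

In this assay, methoxy in place of methyl on the aromatic carbon para to a large group gives no change at the digits printed from compound 2 to compound 3 (within the scatter), so the added oxygen and its hydrogen-bond acceptor leave no mark on the read-out at this position. For the compounds shown here, measured against the hydrogen of compound 1, methoxy gives a 1.6-fold higher number from compound 1 to compound 3 (0.19 log units; within the scatter), so two different groups at this carbon have now been read against hydrogen and neither step leaves the scatter, which makes the flat picture rest on more than the single methyl step. Nothing measured here offers an explanation for this flat response at this position.

Going by these compounds, the three compounds cover only hydrogen, methyl and methoxy at this one carbon, so it remains open whether an amine, a carboxylic acid or a longer chain such as butoxy in the same place would move the number beyond the scatter. Also open, on these data alone, is whether the same changes on the other carbons of this ring would stay as flat as those seen here.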